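This account rests on a few compounds, and the source may have more. Where it says the series, first, only, none or still open, it means among the compounds named here.

Compound 1 `CC(C)NC(=O)N1CCC(CN(C2Cc3cc(C#N)ccc3N(Cc3cncn3C)C2)S(=O)(=O)c2ccccn2)CC1` gives 0.6 10^-6 cm/s in an ADME assay on Caco-2 cells (Homo sapiens) for permeability, in the apical to basolateral direction (a lower number here means that the compound crosses the layer more slowly, a higher number that the compound crosses the layer faster), the highest of the three numbers seen so far. Compound 2 `Cn1cncc1CN1CC(N(CC2CCN(S(C)(=O)=O)CC2)S(=O)(=O)c2ccccn2)Cc2cc(C#N)ccc21` gives 0.1 10^-6 cm/s, and compound 3 `C=C(C)C(=O)N1CCC(CN(C2Cc3cc(C#N)ccc3N(Cc3cncn3C)C2)S(=O)(=O)c2ccccn2)CC1` gives 0.5 10^-6 cm/s; a 6.0-fold lower number from compound 1 to compound 2 (0.78 log units; beyond the scatter), whereas a 1.2-fold lower number from compound 1 to compound 3 (0.08 log units; within the scatter). Compound 4 `Cn1cncc1CN1CC(N(CC2CCN(C(=O)c3ccco3)CC2)S(=O)(=O)c2ccccn2)Cc2cc(C#N)ccc21` is the next member: furan-2-yl in place of isopropylamino on a carbonyl carbon. The step from compound 1 to compound 3, which also replaces the isopropylamino on the carbonyl carbon, stayed within the scatter, and only the methylsulfonyl in place of isopropylcarbamoyl moved the number beyond it. Compound 4 keeps a carbonyl on that ring nitrogen, so compound 4 is expected to show a step of no change at the digits printed from compound 1 to compound 4 (within the scatter), with a number estimated at 0.6 10^-6 cm/s and a range from 0.3 10^-6 cm/s to 1.2 10^-6 cm/s.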

Compound 4, apparent permeability: 0.5 10^-6 cm/s
The estimate for compound 4 lay 1.2-fold (0.08 log units) above the measured number; the measured number falls inside the stated range.
By their numbers in this assay, from the lowest: compound 2; then compounds 3, 4 and 1 (each within the scatter of the next).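

In this assay furan-2-yl on the carbonyl carbon, which brings a ring and drops the hydrogen-bond donor of isopropylamino, gives a 1.2-fold lower number from compound 1 to compound 4 (0.08 log units; within the scatter) and, set against 1-methylethenyl, no change at the digits printed from compound 3 to compound 4 (within the scatter). An aromatic ring at this position therefore joins isopropylamino and 1-methylethenyl within the scatter, while the carbonyl-to-sulfonyl contrast recurs with this new group in a 5.0-fold higher number from compound 2 to compound 4 (0.70 log units; beyond the scatter). Nothing measured here explains these numbers. Still open, on these data alone, is whether a chain ending in a carboxylic acid or a dimethylamino group on that carbonyl carbon would leave the number within the scatter of compound 1.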